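The source may report more compounds than this note shows. Statements on the series, on what has been measured and on what is new or still open speak of the compounds shown alone.

Compound 1 `COc1ncc(-c2ccc3nc(NC(=O)NCCN4CCCC4)sc3c2)cc1NS(=O)(=O)c1ccc(F)cc1` gives 300 nM in a functional assay on A549 cells (Homo sapiens) for antiproliferative activity, read by MTT assay, with a stated time of 72 h; a higher number here means a weaker inhibitor, a lower number a stronger inhibitor.
Compound 2 `COc1ncc(-c2ccc3nc(NC4CC4)sc3c2)cc1NS(=O)(=O)c1ccc(F)cc1` gives 1330 nM in this assay.
Compound 3 `COc1ncc(-c2ccc3nc(NC(=O)NC4CC4)sc3c2)cc1NS(=O)(=O)c1ccc(F)cc1` gives 900 nM in this assay.

Compound 3 stands second highest of the three numbers: its nearest neighbour is compound 2, with a 1.5-fold lower number from compound 2 to compound 3 (0.17 log units; within the scatter) lying within the scatter, while compound 1 is furthest away, with a 3.0-fold higher number from compound 1 to compound 3 (0.48 log units; beyond the scatter) lying beyond it. Compound 4 `CNC(=O)Nc1nc2ccc(-c3cnc(OC)c(NS(=O)(=O)c4ccc(F)cc4)c3)cc2s1` has not yet been measured in this assay. It differs from compound 3 in one place: methyl in place of cyclopropyl on an amide-type nitrogen. The step that bears most directly on this same amide-type nitrogen is a 3.0-fold higher number from compound 1 to compound 3 (0.48 log units; beyond the scatter), a modest rise; a 4.4-fold higher number from compound 1 to compound 2 (0.65 log units; beyond the scatter) also touches this end of the molecule but removes the carbamoyl as well, so it speaks less directly. A further shortening to methyl is expected to bring a small further rise, a 1.4-fold higher number from compound 3 to compound 4 (0.16 log units; within the scatter). Compound 4 is therefore estimated at 1300 nM, with a range from 500 nM to 3500 nM.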

Compound 4, half-maximal inhibitory concentration: 1560 nM
Compound 4: middle estimate off by 1.2-fold (0.08 log units), on the low side; low and high end bracket the measured number.
By their numbers in this assay, from the lowest: compound 1; then compounds 3, 2 and 4 (each within the scatter of the next).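

On the amide-type nitrogen, methyl and cyclopropyl cannot be told apart in this assay (a 1.7-fold higher number from compound 3 to compound 4 (0.24 log units; within the scatter)), and moving from the cyclopropyl amine to the methyl urea also stays within the scatter (a 1.2-fold higher number from compound 2 to compound 4 (0.07 log units; within the scatter)). Only 2-(pyrrolidin-1-yl)ethyl stands apart from the smaller groups, and the gap to methyl is the widest yet (a 5.2-fold higher number from compound 1 to compound 4 (0.72 log units; beyond the scatter)). Nothing measured here explains these numbers.

On these data alone, whether compound 1 owes its lower number to the pyrrolidine or to the length of its chain stays open. A 2-(dimethylamino)ethyl or a plain butyl chain on this nitrogen would separate the two.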